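Lengthening the Propyl Chain with a Cyclopentyl End

The source may hold more compounds than are shown below. What is called first, only, known or untested is meant among the compounds shown, and "the series" means these compounds.

In a functional assay on HT-29 cells (Homo sapiens) for cytotoxicity, read by sulforhodamine B assay, with a stated time of 2 days, tested at 100 uM (a higher number here means more inhibition at the concentration tested (going by the name of the read-out), a lower number less inhibition), the three measured compounds stand as follows:
Compound 1 `COc1cccc(-c2nc3c(-c4ccc(Cl)cc4)n[nH]c3c(=O)n2NC(=O)c2ccccc2)c1` gives 87.3%.
Compound 2 `O=C(Nn1c(-c2ccccc2)nc2c(-c3ccc(Cl)cc3)n[nH]c2c1=O)c1ccccc1` gives 92%.
Compound 3 `CCCc1nc2c(-c3ccc(Cl)cc3)n[nH]c2c(=O)n1NC(=O)c1ccccc1` gives 91.1%.

Compound 3 holds the second highest of the three numbers. Its nearest neighbour is compound 2: a number 0.9 percentage points lower from compound 2 to compound 3 (within the scatter). Its furthest is compound 1: a number 3.8 percentage points higher from compound 1 to compound 3 (within the scatter). The third step, a number 4.7 percentage points higher from compound 1 to compound 2 (within the scatter), is likewise within the scatter, so the three compounds cannot be ranked against one another on these data.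

Compound 4 `O=C(Nn1c(CCC2CCCC2)nc2c(-c3ccc(Cl)cc3)n[nH]c2c1=O)c1ccccc1` carries the change (cyclopentyl in place of methyl on a saturated chain carbon, two bonds along the chain from an aromatic carbon). Among the measured compounds shown here, the step that bears most directly on it is the one from compound 2 to compound 3, where a phenyl at the same aromatic carbon was exchanged for propyl without a shift beyond the scatter; the step from compound 1 to compound 3, 3-methoxyphenyl to propyl, was equally flat. Groups of very different size at this position have thus left this assay unmoved, and the further growth of the chain in compound 4 is expected to do the same, with a step of a number 1.1 percentage points lower from compound 3 to compound 4 (within the scatter) that stays within the scatter.

Compound 4 is therefore estimated at 90%, within a range from 78% to 97%.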

Compound 4, a percentage reported as inhibition, at one concentration (the size of the read-out at that concentration, not a potency): 87.3%
Compound 4: middle estimate off by 2.7 percentage points, on the high side; low and high end bracket the measured number.
By their numbers in this assay, from the lowest: compounds 1, 4, 3 and 2 (each within the scatter of the next).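

In this assay, cyclopentyl in place of methyl at the end of the chain gives a number 3.8 percentage points lower from compound 3 to compound 4 (within the scatter), so adding a five-membered non-aromatic ring there does not carry the number beyond the scatter. Among the compounds shown here, measured against the aromatic groups at the same carbon, 2-cyclopentylethyl in place of phenyl gives a number 4.7 percentage points lower from compound 2 to compound 4 (within the scatter), and in place of 3-methoxyphenyl it gives no change at the digits printed from compound 1 to compound 4 (within the scatter), which adds a chain ending in a saturated ring to the aromatic rings and the plain propyl as a third kind of group with no step here beyond the scatter. No supporting data bear on why this position stays so flat in these compounds.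

The compounds shown leave open whether an amine or a carboxylic acid at the end of the chain, or a group as small as methyl on the same aromatic carbon, would move the number beyond the scatter. As every number comes from one tested concentration, they also leave open whether these compounds would differ in potency across a full range of concentrations.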